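This account rests on a few compounds, and the source may have more. Where it says the series, first, only, none or still open, it means among the compounds named here.

Going by the values given here, in a physicochemical assay for solubility, in phosphate buffer, with a stated time of 18 h, at pH 7.4 (a higher number here means a more soluble compound, a lower number a less soluble compound), three compounds have numbers so far. Compound 1 `Nc1nc(-c2ccccn2)nn1-c1ncnc2cc(OC(F)(F)F)ccc12` gives 3000 nM, compound 3 `COc1cc2ncnc(-n3nc(-c4ccccn4)cc3N)c2cc1OC` gives 1000 nM, and compound 2 `COc1cc2ncnc(-n3nc(-c4cccnc4)nc3N)c2cc1OC` gives 27000 nM. Compound 2 therefore stands highest of the three, and both other values lie below it by more than the usual scatter, with compound 1 the nearer and compound 3 the further. No two of these compounds differ in one place only, so no measured step offers a direct guide.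

Compound 4 `COc1cc2ncnc(-n3nc(N)nc3N)c2cc1OC` arises from compound 2 by a single change, amino in place of pyridin-3-yl on an aromatic carbon, between two ring nitrogen atoms. Among the compounds with values here, with no precedent for this change in the data, only a moderate upward move in this assay is expected, and a result within the scatter would remain plausible. The expected move is a 2.2-fold higher number from compound 2 to compound 4 (0.35 log units; beyond the scatter). For compound 4 the estimated value is 60000 nM, with an expected range from 15000 nM to 200000 nM.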

Compound 4, solubility: 83000 nM
Compound 4: middle estimate off by 1.4-fold (0.14 log units), on the low side; the measured number falls inside the stated range.
By their numbers in this assay, from the lowest: compound 3; then compound 1; then compound 2; then compound 4.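

In this assay, going by these compounds alone, this is the first change read directly, as no two earlier compounds differed in one place only. On an aromatic carbon between two ring nitrogen atoms, amino in place of pyridin-3-yl gives a 3.1-fold higher number from compound 2 to compound 4 (0.49 log units; beyond the scatter), so the six-membered aromatic ring can leave this position and the number still rises, although the step is modest. No measurement shown explains this rise.

The compounds shown cannot separate the departure of pyridin-3-yl from the arrival of amino, since no other group, such as a methyl group, a morpholine or a carboxylic acid, stands at this carbon. They also leave open whether amino at this position would give a similar rise on the core of compound 1.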